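Second Chloro on the Core: What Cell Tolerance to Expect

The compounds below may be only part of what the source reports. "The series", "measured", "known", "first", "only" and "open" are said of these compounds alone.

Compound 1 `ClCc1ccc(Cn2cnc3c(Cl)ncnc32)cc1` gives 7410 nM in a functional assay on U-251 cells (Homo sapiens) for cytotoxicity, read by sulforhodamine B assay, with a stated time of 48 h; a higher number here means that more compound is tolerated, a lower number that less compound is tolerated
Compound 2 `ClCc1cccc(Cn2cnc3c(Cl)ncnc32)c1` gives 6760 nM in this assay

Among the two measured compounds, compound 1 stands with the highest number in this assay, yet its nearest neighbour, compound 2, differs from it only within the usual scatter, so the two values cannot be told apart and neither compound can be called the better tolerated.

Compound 3 `ClCc1ccc(Cn2cnc3c(Cl)nc(Cl)nc32)cc1` has not yet been measured. It differs from compound 1 in one place: chloro in place of hydrogen on an aromatic carbon. The new chloro sits on an aromatic carbon of a six-membered aromatic ring with two nitrogen atoms, part of the fused core, between two ring nitrogen atoms and meta to the chloro already present there.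

Among the measured compounds shown here, no measured pair shows what such a change does in this assay, so the size and direction of the step are open. A modest shift in either direction, or none beyond the scatter, is the reasonable expectation. On that basis compound 3 is estimated at 5500 nM, within 1800 nM to 16000 nM, which corresponds to an expected 1.3-fold lower number from compound 1 to compound 3 (0.13 log units; within the scatter).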

Compound 3, concentration lethal to 50% of the cells: 7410 nM
Estimate against measurement, compound 3: 1.3-fold (0.13 log units) below, within the range that was stated.
By their numbers in this assay, from the lowest: compounds 2, 1 and 3 (each within the scatter of the next).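

Placing a chloro in place of hydrogen on the aromatic carbon between two ring nitrogen atoms gives, in this assay, no change at the digits printed from compound 1 to compound 3 (within the scatter), and this is the first measured step at this position of the shared core. On this one pair, a second chloro on the core, meta to the chloro already present, leaves the cell tolerance unmoved, so adding this single heavy atom here does not by itself separate compound 3 from compound 1 in this measurement. No measured information at hand explains why the number holds at this position, so the result stands as an observation without a stated cause.

As far as these compounds go, what an amine or a methoxy group would do on this same carbon stays open, since a single chloro cannot show whether every replacement of this hydrogen would be met the same way. From the compounds shown here alone, it is also open whether the same chloro step would read alike on compound 2, whose chloromethyl group sits elsewhere on the benzene ring, as this step has been read only from compound 1.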